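The compounds below may be only part of what the source reports. "The series", "measured", "known", "first", "only" and "open" are said of these compounds alone.

Measured so far:
- compound 1, `O=C(N/N=C/c1ccccc1)c1cccnc1`: > 100 ug/mL
- compound 2, `O=C(N/N=C/c1cccc(Cl)c1)c1cccnc1`: > 100 ug/mL

In an ADME assay on HEL cells (Homo sapiens) for cytotoxicity, read by microscopy (a lower number here means that less compound is tolerated, a higher number that more compound is tolerated), compound 1 stands only at a limit: its result of > 100 ug/mL is the highest concentration tested, not a measured number. For compound 2 the result of > 100 ug/mL is likewise a limit. For the measured compounds named here, the one measured change, a step that the two limits leave unreadable from compound 1 to compound 2, therefore cannot be sized: both ends of it rest on (the limit of > 100 ug/mL in this assay, at which 2 of the 2 values shown sit).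

Compound 3, `O=C(N/N=C/c1ccccc1[N+](=O)[O-])c1cccnc1`, differs from compound 1 in one place: nitro in place of hydrogen on an aromatic carbon. Going by the values given here, no measured step matches this change, and the single step that exists, the one from compound 1 to compound 2, is unreadable in size. There is thus no basis for expecting a shift in this assay beyond the scatter in either direction, and the most that can be said is that both measured compounds were tolerated up to the top of the tested range.

On that basis compound 3 is estimated to reach 100 ug/mL, within a range from 50 ug/mL to 200 ug/mL, most likely again as a limit rather than a number. This estimate means an expected step of a number no higher from compound 1 to compound 3 (the limit leaves the size open).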

Compound 3, minimum cytotoxic concentration: > 100 ug/mL
Compound 3 was reported as a limit (the forecaster's own chance of this, stated with the estimate: 75%); the middle value sits exactly at the limit.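

The result for compound 3 in this assay is a limit, as is that of compound 1, so the step between them cannot be read: the limit of > 100 ug/mL in this assay, at which 3 of the 3 values shown sit.

The compounds shown leave open the concentration at which compound 1, compound 2 or compound 3 would become toxic to these cells, and whether chloro or nitro in place of hydrogen changes that concentration.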